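Benzoyl on the amine nitrogen of compound 2

A few compounds are considered here, and "the series" means these few. Any claim that something is new, unique, unknown or untested is made for them only; others in the source may bear on it.

compound 1 `N=c1oc2ccccc2cc1C(=O)N/N=C1\C(=O)Nc2ccc(S(=O)(=O)N3CCOCC3)cc21`: 7820 nM
compound 2 `N/N=C1\C(=O)Nc2ccc(S(=O)(=O)N3CCOCC3)cc21`: 32400 nM

Both values come from a functional assay on HepG2 cells (Homo sapiens) for cytotoxicity, read by sulforhodamine B assay, with a stated time of 24 h; a lower number here means a stronger inhibitor, a higher number a weaker inhibitor. Compound 2, at 32400 nM, has the higher of the two numbers, and compound 1 lies below it by more than the scatter.

The next compound is compound 3 `O=C1Nc2ccc(S(=O)(=O)N3CCOCC3)cc2/C1=N/NC(=O)c1ccccc1`, which carries benzoyl in place of hydrogen on an amine nitrogen of compound 2 (benzoyl in place of hydrogen on an amine nitrogen). Within the data shown here, no measured pair shows this change alone. Among the measured compounds shown here, the only guide is compound 1 at 7820 nM, the lower number of the two. A step towards a lower number in this assay is therefore expected, probably no larger than the gap between the two measured compounds. The expected change is a 2.2-fold lower number from compound 2 to compound 3 (0.33 log units; beyond the scatter). For compound 3 the estimated value is 15000 nM, with an expected range of 6000 nM to 35000 nM.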

Compound 3, half-maximal inhibitory concentration: 18100 nM
The estimate for compound 3 lay 1.2-fold (0.08 log units) below the measured number; the measured number falls inside the stated range.
By their numbers in this assay, from the lowest: compound 1; then compounds 3 and 2 (each within the scatter of the next).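

In this assay benzoyl in place of hydrogen on the amine nitrogen gives a 1.8-fold lower number from compound 2 to compound 3 (0.25 log units; within the scatter) and so does not clearly separate the two compounds. On the carbonyl carbon, the group of 6 heavy atoms in place of the group of 11 heavy atoms gives a 2.3-fold higher number from compound 1 to compound 3 (0.36 log units; beyond the scatter) as a modest step beyond the scatter, which shows that the group on this carbonyl carbon matters in this assay and that a benzoyl-type aromatic ring alone does not reproduce the number of compound 1. No evidence on the origin of either step is available. Still open, from the compounds shown here alone, is whether acetyl on the same nitrogen would give a number distinct from those of compound 2 and compound 3. Also open, going by these compounds, is how a benzoyl group carrying an amine or a carboxylic acid would read in this assay.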